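Cytotoxicity outlook for an isopropyl analogue of compound 2

This account rests on a few compounds, and the source may have more. Where it says the series, first, only, none or still open, it means among the compounds named here.

Compound 2 `CN1C(=O)C(C2=NS(=O)(=O)c3cc(NS(C)(=O)=O)ccc3N2)=C(O)C2CCCC21` has no result reported in an ADME assay on Huh-7 cells (Homo sapiens) for cytotoxicity, with a stated time of 72 h; a lower number here means that less compound is tolerated, a higher number that more compound is tolerated; its entry there reads "not determined" (no result reported). Among the measured compounds shown here, the only value shown for the series is a limit of the assay: compound 1 `CS(=O)(=O)Nc1ccc2c(c1)S(=O)(=O)N=C(C1=C(O)C3CCCC3N(Cc3ccc(F)cn3)C1=O)N2` gives > 33000 nM in this assay. Compound 3 `CC(C)N1C(=O)C(C2=NS(=O)(=O)c3cc(NS(C)(=O)=O)ccc3N2)=C(O)C2CCCC21` differs from compound 2 by isopropyl in place of methyl on an amide-type nitrogen in a ring. For the measured compounds named here, with no measured step available, no shift beyond the scatter is expected in this assay in either direction. Given (the limit of > 33000 nM in this assay, at which 1 of the 2 values shown sits), compound 3 is estimated to give 33000 nM, with a range of 10000 nM to 100000 nM.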

Compound 3, half-maximal cytotoxic concentration: > 33000 nM
Compound 3 gave a limit, no number; the forecaster's own chance of this, stated with the estimate: 70%; the middle value lies on the limit itself.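

Compound 1 and compound 3 each gave only a limit in this assay, so the step between them cannot be read. The compounds shown leave open whether the group on the amide-type nitrogen changes cytotoxicity at all.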